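Nitrile for nitro in a cyclic thiourea series

This account rests on a few compounds, and the source may have more. Where it says the series, first, only, none or still open, it means among the compounds named here.

Compound 1 `CC(O)(CSc1ccc(S(F)(F)(F)(F)F)cc1)C(=O)Nc1ccc(C#N)c(C(F)(F)F)c1`: 30200 nM
Compound 2 `CC(O)(CSc1ccc(S(F)(F)(F)(F)F)cc1)C(=O)Nc1ccc([N+](=O)[O-])c(C(F)(F)F)c1`: 10100 nM
Compound 3 `CC1(C)C(=O)N(c2ccc([N+](=O)[O-])c(C(F)(F)F)c2)C(=S)N1c1cccc(S(F)(F)(F)(F)F)c1`: 100000 nM

Of the compounds shown here, three have been measured in a functional assay on VCaP cells (Homo sapiens) for antiproliferative activity, read by propidium iodide staining, with a stated time of 96 h; a lower number here means a stronger inhibitor, a higher number a weaker inhibitor. Compound 2 gives 10100 nM. Where compound 2 carries a nitro group, compound 1 carries a nitrile, and compound 1 gives 30200 nM. The change between them is cyano in place of nitro on an aromatic carbon, and it made a 3.0-fold higher number from compound 2 to compound 1 (0.48 log units; beyond the scatter). Compound 3 has a different core from compound 2; the difference between the two cores is not broken down here. In this assay compound 3 gives 100000 nM, the highest number among the three measured compounds.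

Compound 4 `CC1(C)C(=O)N(c2ccc(C#N)c(C(F)(F)F)c2)C(=S)N1c1cccc(S(F)(F)(F)(F)F)c1` has not yet been measured. It differs from compound 3 by cyano in place of nitro on an aromatic carbon, which is the same change as that from compound 2 to compound 1, at the same place on the ring. Because that earlier step was a 3.0-fold higher number from compound 2 to compound 1 (0.48 log units; beyond the scatter), a higher number would be expected for compound 4 than for compound 3 as well. However, compound 3 already stands at the highest number given in this assay, so the expectation rests on a single earlier step carried onto a core that is itself weak, and the assay may report only a limit for compound 4. The step from compound 3 to compound 4 is estimated at no change at the digits printed from compound 3 to compound 4 (within the scatter), and compound 4 is expected to give 100000 nM, with a range from 40000 nM to 300000 nM.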

Compound 4, half-maximal inhibitory concentration: 100000 nM
Compound 4: the middle estimate sits on the measured number at the digits printed, and the stated range covers the measured number.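

On the core of compound 3, cyano in place of nitro on an aromatic carbon gave no change at the digits printed from compound 3 to compound 4 (within the scatter) in this assay. The same change at the same place on the ring therefore did not give the same result on the two cores, and the gap between the two steps is larger than repeat measurements would account for: the same change on two cores in this assay, a 3.0-fold higher number (0.48 log units; beyond the scatter) from compound 2 to compound 1 and no change at the digits printed (within the scatter) from compound 3 to compound 4, 3.0-fold (0.48 log units) apart, beyond the scatter of two such steps. This shows that the size of the step seen on the core of compound 2 did not carry over to the core of compound 3, but with a single pair on each core it does not show why the two steps differ, or what the step would be on any further core.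

The compounds shown leave open how a replacement other than nitrile would behave at this place on each core, for example a chlorine atom, an amine or a carboxylic acid. They also leave open whether a longer chain or an amine on the other aromatic ring would move the numbers on the two cores together or separately, and whether the cyano and nitro pairs would then stay as far apart as they do here.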